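The compounds below may be only part of what the source reports. "The series", "measured", "known", "first", "only" and "open" are said of these compounds alone.

Within the data shown here, compound 2 `CC1=NC(C)=C([N+](=O)[O-])C(c2ncccc2[N+](=O)[O-])/C1=C(/O)OCCc1ccccc1` is one of only two compounds measured in a functional assay (muscle tissue) with Cavia porcellus as the target (on this read-out higher numbers stand for weaker inhibition and lower numbers for stronger inhibition), and in this assay compound 2 gives 77700 nM. Its nearest neighbour is compound 1 `CC1=NC(C)=C([N+](=O)[O-])C(c2ccccn2)/C1=C(/O)OCCc1ccccc1`, which in this assay gives 639 nM. The two differ in a single place: the step of a 120-fold higher number from compound 1 to compound 2 (2.08 log units; beyond the scatter) puts a nitro in place of hydrogen on an aromatic carbon, and compound 2 thereby stands at the highest number of the two. Compound 3 `CC1=NC(C)=C([N+](=O)[O-])C(c2ncccc2-c2ccccc2)/C1=C(/O)OCCc1ccccc1` has not yet been measured. It differs from compound 2 by phenyl in place of nitro on an aromatic carbon. Among the measured compounds shown here, the only measured step that bears on this change is the one from compound 1 to compound 2, and it was large. Taking the nitro away again is expected to undo part of that step, but a phenyl enters at the same place, and nothing measured shows what that does. The estimate for compound 3 is therefore a 19-fold lower number from compound 2 to compound 3 (1.29 log units; beyond the scatter) in this assay. Compound 3 is expected to give 4000 nM, with a range from 400 nM to 40000 nM.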

Compound 3, half-maximal inhibitory concentration: 3350 nM
Compound 3: the middle estimate sits 1.2-fold (0.08 log units) above what was measured; measured number inside the range.
By their numbers in this assay, from the lowest: compound 1; then compound 3; then compound 2.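

The high number of the nitro compound does not hold for every group placed here, two atoms from the ring nitrogen: in this assay, phenyl in place of nitro gives a 23-fold lower number from compound 2 to compound 3 (1.37 log units; beyond the scatter) and so recovers much of the inhibition, even though a whole carbon ring now sits at that spot. Hydrogen still remains the best of the three groups seen at this place, since adding phenyl to the core of compound 1 gives a 5.2-fold higher number from compound 1 to compound 3 (0.72 log units; beyond the scatter) and this modest step is far shorter than the large one that nitro causes. Nothing available here explains why nitro and phenyl differ so much at this position.

As far as these compounds go, with only hydrogen, nitro and phenyl to compare, it remains open whether any group at this place can bring the number below that of hydrogen, for example a methyl, a methoxy or an amine. It is also unknown how the phenyl ring itself would respond to a further group, such as a chlorine or a carboxylic acid on that ring.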